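Cytotoxicity notes: biaryl amides, pyridyl versus oxadiazolylphenyl

The source may hold more compounds than are shown below. What is called first, only, known or untested is meant among the compounds shown, and "the series" means these compounds.

Measured so far:
compound 1 `CC(C)N(Cc1cccc(OCCCCCC(=O)O)c1)C(=O)c1ccc(-c2cccc3ccccc23)cc1` — > 26000 nM
compound 2 `CCOC(=O)CCCCCOc1cccc(CN(C(=O)c2ccc(-c3cccnc3)cc2)C(C)C)c1` — > 26000 nM

In an ADME assay on HEK293 cells (Homo sapiens) for cytotoxicity, read by CellTiter-Glo and resazurin assay, with a stated time of 72 h (a lower number here means that less compound is needed, a higher number that more compound is needed for the effect), compound 1 gives > 26000 nM, which is a limit of the assay rather than a number. Compound 2 likewise reaches only a limit in this assay, > 26000 nM. Both values therefore stand at the limit of > 26000 nM in this assay, at which 2 of the 2 values shown sit, and nothing more than that can be read from the pair.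

Compound 3 `CCOC(=O)CCCCCOc1cccc(CN(C(=O)c2ccc(-c3cccc(-c4nnc(C)o4)c3)cc2)C(C)C)c1` has not yet been measured in this assay. It differs from compound 2 by 3-(5-methyl-1,3,4-oxadiazol-2-yl)phenyl in place of pyridin-3-yl on an aromatic carbon.

Going by the values given here, no measured step is available to size this change. Given that compound 2 sits at the limit, the step that the limit leaves unreadable from compound 2 to compound 3 is expected to be none beyond the scatter, with a limit again the most likely report. Compound 3 is accordingly estimated at 40000 nM in this assay, within a range from 15000 nM to 100000 nM.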

Compound 3, half-maximal effective concentration: > 26000 nM
Compound 3 ended at the assay's limit; the forecaster's own chance of this, stated with the estimate: 80%; the middle value does not contradict the limit.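

Between compound 2 and compound 3 no step can be read, since each reports only a limit and not a number: the limit of > 26000 nM in this assay, at which 3 of the 3 values shown sit. The compounds shown leave open whether any member of the series reaches a measurable cytotoxic concentration, and how this change would then register.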